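The source may report more compounds than this note shows. Statements on the series, on what has been measured and on what is new or still open speak of the compounds shown alone.

Measured in a physicochemical assay for lipophilicity, at pH 7.4; on this read-out higher numbers stand for higher lipophilicity and lower numbers for lower lipophilicity:

- compound 1 `C[C@H]1C[C@@H](c2ccncc2NC(=O)c2nc(-c3c(F)cccc3F)ncc2N)C[C@@H](O)[C@@]1(O)CF`: 1.4
- compound 2 `C[C@H]1C[C@@H](c2ccncc2NC(=O)c2ccnc(-c3c(F)cccc3F)n2)C[C@@H](O)[C@]1(C)O`: 1.3

Only these two numbers are available so far. Compound 2, at 1.3, lies within the scatter of compound 1, at 1.4, so the two cannot be told apart on this assay.

The next compound to be measured is compound 3 `C[C@H]1C[C@@H](c2ccncc2NC(=O)c2nc(-c3c(F)cccc3F)ncc2N)C[C@@H](O)[C@]1(C)O`. It differs from compound 2 in one place, with amino in place of hydrogen on an aromatic carbon. Going by the values given here, no measured pair shows this change on its own, so the data give no direct guide to its size or direction. The only footing is the narrow span of the two known values, compound 1 at 1.4 and compound 2 at 1.3. On that footing, no step beyond the scatter is expected in this assay, though a larger move in either direction cannot be ruled out.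

The estimate amounts to an expected step of a number 0.10 log units higher from compound 2 to compound 3 (within the scatter). For compound 3 the expected value is 1.4, with an estimated range from 1 to 1.8.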

Compound 3, distribution coefficient: 2.8
Estimate against measurement, compound 3: 1.40 log units below; the measured number lies above the stated range.
By their numbers in this assay, from the lowest: compounds 2 and 1 (each within the scatter of the next); then compound 3.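

In this assay, the first single-place change shows that this aromatic carbon, ortho to a large group and para to the 2,6-difluorophenyl group, is far from indifferent: amino in place of hydrogen gives a number 1.50 log units higher from compound 2 to compound 3 (beyond the scatter), a large step beyond the scatter, even though the entering group brings a hydrogen-bond donor and a hydrogen-bond acceptor by count. The saturated side of the molecule proves just as responsive with the amino group in place, since hydrogen in place of fluoro on the saturated chain carbon gives a number 1.40 log units higher from compound 1 to compound 3 (beyond the scatter), also large and beyond the scatter, so compound 3 stands clear of both of its neighbours. Nothing at hand accounts for either step, and the size and direction remain observations without an explanation.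

The compounds shown leave open whether the amino step would keep its size with the fluoro group present on the chain carbon, as each change has been seen only once and in one setting. They also leave open how a methyl, a hydroxyl or a dimethylamino group on the same aromatic carbon would compare with the amino group.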